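This account rests on a few compounds, and the source may have more. Where it says the series, first, only, none or still open, it means among the compounds named here.

Measured so far in a functional assay on KYSE-450 cells (Homo sapiens) for inhibition, read by CCK-8 assay, with a stated time of 48 h (on this read-out higher numbers stand for weaker inhibition and lower numbers for stronger inhibition), on the shared core:
- compound 1 `COc1ccc(CN(C(=O)CSC(=S)N2CCN(C(=O)OC(C)(C)C)CC2)c2cc(OC)c(OC)c(OC)c2)cc1` gives 250 nM
- compound 2 `COc1ccc(CN(C(=O)CSC(=S)N2CCN(C(=O)OC(C)(C)C)CC2)c2cc(OC)c(OC)c(OC)c2)cc1F` gives 2410 nM
- compound 3 `COc1ccc(CN(C(=O)CSC(=S)N2CCN(C(=O)OC(C)(C)C)CC2)c2cc(OC)c(OC)c(OC)c2)cc1[N+](=O)[O-]` gives 810 nM

Compound 3 stands in the middle of the three numbers, with compound 2 on its higher side and compound 1 on its lower side. Compound 4 `COc1ccc(CN(C(=O)CSC(=S)N2CCN(C(=O)OC(C)(C)C)CC2)c2cc(OC)c(OC)c(OC)c2)cc1N=[N+]=[N-]` carries azido in place of nitro on an aromatic carbon, ortho to a methoxy group and meta to a large group (azido in place of nitro on an aromatic carbon).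

Among the compounds with values here, no measured step covers this exchange directly, but three bear on it. Nitro in place of hydrogen gave (a 3.2-fold higher number from compound 1 to compound 3 (0.51 log units; beyond the scatter)), fluoro in place of hydrogen gave (a 9.6-fold higher number from compound 1 to compound 2 (0.98 log units; beyond the scatter)) and nitro in place of fluoro gave (a 3.0-fold lower number from compound 2 to compound 3 (0.47 log units; beyond the scatter)). All three are modest. Replacing one non-hydrogen group by another has so far moved the number by the size of that last step, so a shift of that size in either direction remains possible. The data give no direction for azido. The expected change is a 1.1-fold higher number from compound 3 to compound 4 (0.05 log units; within the scatter) as a central guess, with no clear step anticipated in this assay and a wide margin around it. Compound 4 is estimated at 900 nM with an expected range of 280 nM to 2800 nM on this evidence.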

Compound 4, half-maximal inhibitory concentration: 840 nM
Compound 4: middle estimate off by 1.1-fold (0.03 log units), on the high side; the range from low to high includes it.
By their numbers in this assay, from the lowest: compound 1; then compounds 3 and 4 (each within the scatter of the next); then compound 2.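

In this assay, azido and nitro on this aromatic carbon, ortho to a methoxy group, cannot be told apart (a 1.0-fold higher number from compound 3 to compound 4 (0.02 log units; within the scatter)), so this exchange of one three-heavy-atom group for another, with nitrogen replacing both oxygens, leaves the number within the scatter. Azido also falls on the same side as nitro relative to the other two compounds (a 3.4-fold higher number from compound 1 to compound 4 (0.53 log units; beyond the scatter); a 2.9-fold lower number from compound 2 to compound 4 (0.46 log units; beyond the scatter)), so all three non-hydrogen groups shown give a higher number than hydrogen, and fluoro stands apart from azido and nitro with the highest number of the four. No measured property of these compounds is available to account for this result.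

As far as these compounds go, whether an amine or a carboxylic acid on the same carbon would stay level with compound 3 and compound 4 or move towards compound 1 remains open. Also open, from the compounds shown here alone, is whether azido and nitro would still match with an ethoxy group in place of the methoxy group.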